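Swapping a para substituent on the benzyl ring

The source may hold more compounds than are shown below. What is called first, only, known or untested is meant among the compounds shown, and "the series" means these compounds.

Measured so far:
compound 1 `Cc1cc(Nc2nn(Cc3cccnc3)c(=O)c3ccccc23)n[nH]1` — 2900 nM
compound 2 `Cc1cc(Nc2nn(Cc3cc(F)ccc3F)c(=O)c3ccccc23)n[nH]1` — 570 nM
compound 3 `CC(=O)Nc1ccc(Cn2nc(Nc3cc(C)[nH]n3)c3ccccc3c2=O)cc1` — 4200 nM

In a functional assay on HCT-116 cells (Homo sapiens) for cytotoxicity, read by CellTiter-Glo, with a stated time of 5 days (on this read-out higher numbers stand for weaker inhibition and lower numbers for stronger inhibition), compound 3 gives the highest of the three numbers, although compound 1 sits within the scatter of it, while compound 2 lies clearly lower. Compound 4 `Cc1cc(Nc2nn(Cc3ccc([N+](=O)[O-])cc3)c(=O)c3ccccc23)n[nH]1` differs from compound 3 by nitro in place of acetamido on an aromatic carbon. Within the data shown here, only one measured step touches the same region: a 5.1-fold lower number from compound 1 to compound 2 (0.71 log units; beyond the scatter), which changed the whole ring rather than one group on it. That step shows this region can move the read-out modestly, but nothing measured bears directly on nitro against acetamido. The expected step is therefore modest at most, a 1.7-fold lower number from compound 3 to compound 4 (0.23 log units; within the scatter), with direction uncertain. Compound 4 is estimated at 2500 nM, within 800 nM to 8000 nM.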

Compound 4, half-maximal inhibitory concentration: 1400 nM
Beside the measured number, compound 4's estimate is 1.8-fold (0.25 log units) above it, and the stated range covers the measured number.
By their numbers in this assay, from the lowest: compound 2; then compound 4; then compounds 1 and 3 (each within the scatter of the next).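

Changing only the group on this aromatic carbon matters in this assay: nitro in place of acetamido gives a 3.0-fold lower number from compound 3 to compound 4 (0.48 log units; beyond the scatter), so one substituent can shift the read-out without replacing the whole ring. Among the ring swaps, 4-nitrophenyl gives a 2.1-fold lower number from compound 1 to compound 4 (0.32 log units; beyond the scatter) against pyridin-3-yl, but a 2.5-fold higher number from compound 2 to compound 4 (0.39 log units; beyond the scatter) against 2,5-difluorophenyl. No measurement shown gives a cause for these steps.

Going by these compounds, whether the step follows from adding nitro or from losing acetamido remains open. An amine or a carboxylic acid on this carbon would test how far the trend extends.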